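A few compounds are considered here, and "the series" means these few. Any claim that something is new, unique, unknown or untested is made for them only; others in the source may bear on it.

Compound 1 `COc1cc2c(cc1OC)C(CC(=O)Nc1cccc(Cl)c1)CC2`: in a functional assay on the whole organism (strain Wistar) for inhibition, with Rattus norvegicus as the target, read by paw edema, with a stated time of 2 h, at a dose of 100 mg/kg (on this read-out lower numbers stand for less inhibition and higher numbers for more inhibition at the one dose given (going by the name of the read-out)), compound 1 gives 28%.
Compound 2 `COc1cc2c(cc1OC)C(CC(=O)Nc1ccc(Br)cc1)CC2`: in this assay compound 2 gives 40%.

Compound 2 stands highest of the two measured numbers, its nearest neighbour being compound 1, lower by a number 12 percentage points higher from compound 1 to compound 2 (beyond the scatter). Compound 3 `COc1cc2c(cc1OC)C(CC(=O)Nc1ccc(C)cc1)CC2` differs from compound 2 by methyl in place of bromo on an aromatic carbon. For the measured compounds named here, no measured step exchanges bromo for methyl at the same place; the one measured step, a number 12 percentage points higher from compound 1 to compound 2 (beyond the scatter), changes both the halogen and its position and so bears only loosely on this change. In this assay compound 3 is therefore expected to change by a number 5 percentage points lower from compound 2 to compound 3 (within the scatter), that is, no step beyond the scatter. The estimate for compound 3 is 35%, ranging from 22% to 48%.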

Compound 3, a percentage reported as inhibition, in the whole organism at one dose (the size of the read-out at that dose, not a potency): 26%
The estimate for compound 3 lay 9 percentage points above the measured number, and the stated range covers the measured number.
By their numbers in this assay, from the lowest: compounds 3 and 1 (each within the scatter of the next); then compound 2.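

With the group kept on the same aromatic carbon, para to a large group, methyl in place of bromo gives a number 14 percentage points lower from compound 2 to compound 3 (beyond the scatter) in this assay, so the identity of this group alone moves the number. For the compounds shown here, the other step, a number 2 percentage points lower from compound 1 to compound 3 (within the scatter), shows that the 4-methylphenyl group keeps no advantage over the 3-chlorophenyl group, which leaves bromo as the only group here with a number beyond the scatter of the others. Nothing available explains why the two groups differ.

On these data alone, whether an amine or a carboxylic acid on this carbon would match bromo remains open. So does whether the 4-bromophenyl result holds at other doses or times.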